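Swapping the sulfur-linked heteroaryl for an isoquinolinyl ether

The compounds below may be only part of what the source reports. "The series", "measured", "known", "first", "only" and "open" are said of these compounds alone.

Measured so far in a functional assay on Jurkat cells (Homo sapiens) for inhibition; a lower number here means a stronger inhibitor, a higher number a weaker inhibitor:
Compound 1, `CC(C)[C@H](NC(=O)COc1cccc2ccccc12)C(=O)N[C@@H](CC(=O)O)C(=O)CSc1ncc[nH]1`, gives the limit > 200000 nM and no number.
Compound 2, `CC(C)[C@H](NC(=O)COc1cccc2ccccc12)C(=O)N[C@@H](CC(=O)O)C(=O)CSc1nnc(-c2ccccc2)o1`, gives 150000 nM.
Compound 3, `CC(C)[C@H](NC(=O)COc1cccc2ccccc12)C(=O)N[C@@H](CC(=O)O)C(=O)CSc1nccc(C(F)(F)F)n1`, gives the limit > 200000 nM and no number.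

Compound 3 therefore stands at the edge of what this assay can report, a position it shares with compound 1 (the limit of > 200000 nM in this assay, at which 2 of the 3 values shown sit). Compound 4, `CC(C)[C@H](NC(=O)COc1cccc2ccccc12)C(=O)N[C@@H](CC(=O)O)C(=O)COc1nccc2ccccc12`, differs from compound 3 in one place: (isoquinolin-1-yl)oxy in place of (4-(trifluoromethyl)pyrimidin-2-yl)sulfanyl on a saturated chain carbon bound to a carbonyl carbon.

The measured steps that touch compound 3 are both weak guides. a step that the two limits leave unreadable from compound 1 to compound 3, because both ends are limits. an at least 1.3-fold higher number from compound 2 to compound 3 (0.12 log units; that floor lies within the scatter), and that floor lies within the scatter. Every change tried so far at this sulfur-bound group has left the number near or beyond the limit, so nothing here points to a large gain from another swap at the same place.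

The expectation for compound 4 is a step of a number no higher from compound 3 to compound 4 (the limit leaves the size open), that is, no change beyond the scatter. The estimated value for compound 4 in this assay is 200000 nM, within 60000 nM to 600000 nM, with a real chance that only a limit is reported.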

Compound 4, half-maximal inhibitory concentration: 106000 nM
Compound 4: middle estimate off by 1.9-fold (0.28 log units), on the high side; the range from low to high includes it.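

In this assay, compound 4 gives 106000 nM, which shows that an oxygen-linked (isoquinolin-1-yl)oxy group can stand on this saturated chain carbon and still give a measured number. Even so, the change brings no clear gain: an at least 1.8-fold lower number from compound 3 to compound 4 (0.27 log units; that floor lies within the scatter), an at least 1.8-fold lower number from compound 1 to compound 4 (0.27 log units; that floor lies within the scatter), and a 1.4-fold lower number from compound 2 to compound 4 (0.15 log units; within the scatter). The first two steps are only floors because compound 1 and compound 3 each give a limit rather than a number: the limit of > 200000 nM in this assay, at which 2 of the 4 values shown sit.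

Compound 4 changes the linking atom and the ring together, so the compounds shown cannot separate the effect of sulfur giving way to oxygen from that of the new ring. An (isoquinolin-1-yl)sulfanyl group would separate the two, and a phenoxy group would test whether the second ring of the isoquinoline matters at all.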